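A few compounds are considered here, and "the series" means these few. Any claim that something is new, unique, unknown or untested is made for them only; others in the source may bear on it.

The series shares one core; compound 1 has the structure `COc1cc(-c2nn(-c3cccc(NC(=O)c4ccc(Cl)c(C(F)(F)F)c4)c3)cc2-c2ccncc2)ccc1Cl`, compound 2 the structure `O=C(Nc1cccc(-n2cc(-c3ccncc3)c(-c3ccc(Cl)c(O)c3)n2)c1)Nc1cc(C(F)(F)F)cc(C(F)(F)F)c1`, and compound 3 the structure `O=C(Nc1cccc(-n2cc(-c3ccncc3)c(-c3ccc(Cl)c(O)c3)n2)c1)Nc1ccc(Cl)c(C(F)(F)F)c1`. Among the measured compounds shown here, in a functional assay on OVCAR-8 cells (Homo sapiens) for inhibition, read by sulforhodamine B assay, with a stated time of 48 h (a lower number here means that less compound is tolerated, a higher number that more compound is tolerated), compound 2 gives 43700 nM, the only measured number among the three. For compound 1 this assay reports only a limit, > 32500 nM. For compound 3 this assay likewise reports only a limit, > 32500 nM. For the measured compounds named here, compound 2 therefore stands as the single compound with a read number, and that number lies close to the limit at which the other two sit (the limit of > 32500 nM in this assay, at which 2 of the 3 values shown sit). Going by the values given here, no pair of measured compounds differs in a single place, so no measured step is available.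

Compound 4, with the structure `COc1cc(-c2nn(-c3cccc(NC(=O)Nc4cc(C(F)(F)F)cc(C(F)(F)F)c4)c3)cc2-c2ccncc2)ccc1Cl`, differs from compound 2 in one place: methyl in place of hydrogen on an oxygen on an aromatic ring. Among the compounds with values here, compound 2 gives 43700 nM and no measured step bears on this change. The step is therefore expected to stay within the scatter, so compound 4 is expected to give 40000 nM, between 20000 nM and 80000 nM, with the expected step of a 1.1-fold lower number from compound 2 to compound 4 (0.04 log units; within the scatter).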

Compound 4, concentration lethal to 50% of the cells: > 50000 nM
Compound 4 was reported as a limit; the forecaster's own chance of this, stated with the estimate: 55%; middle value at least 1.2-fold (0.09 log units) from the limit.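

Among the compounds shown here, the step of an at least 1.1-fold higher number from compound 2 to compound 4 (0.05 log units; that floor lies within the scatter) is the first measured comparison between two compounds that differ in one place, here hydroxy to methoxy on the 4-chloro-3-hydroxyphenyl group. Placing methyl on this oxygen does not bring the number in this assay down, although the floor of the step lies within the scatter and so does not show a real rise. Compound 4 gives > 50000 nM, which is a limit and not a number, so only the floor of the step can be read: the limit of > 50000 nM in this assay, at which 1 of the 4 values shown sits.

The compounds shown leave open how far the true value of compound 4 lies from that limit. They also leave open whether a longer chain on this oxygen, or an amine in place of the hydroxy, would shift the number in this assay.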